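From cyclohexyl to 4-fluorophenyl at the assay limit

The compounds below may be only part of what the source reports. "The series", "measured", "known", "first", "only" and "open" are said of these compounds alone.

Compound 1 (`O=C1COc2ccc(-c3cnc(Cl)c(NS(=O)(=O)c4ccc(F)cc4)c3)cc2N1C1CCCCC1`) was tested in a functional assay on HepG2 cells (Homo sapiens) for antiproliferative activity, read by MTT assay, with a stated time of 72 h; on this read-out lower numbers stand for stronger inhibition and higher numbers for weaker inhibition. There compound 1 gives > 40000 nM, which is a limit and not a number. Compound 2 (`COc1ncc(-c2ccc3c(c2)N(C2CCCCC2)C(=O)CO3)cc1NS(=O)(=O)c1ccc(F)cc1`), with methoxy in place of chloro on an aromatic carbon, gives > 40000 nM, again a limit. Compound 1 therefore stands at the limit of > 40000 nM in this assay, at which 2 of the 2 values shown sit. Among the compounds with values here, the only measured step is a step that the two limits leave unreadable from compound 1 to compound 2, so it offers no size to carry forward.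

Compound 3 (`O=C1COc2ccc(-c3cnc(Cl)c(NS(=O)(=O)c4ccc(F)cc4)c3)cc2N1c1ccc(F)cc1`) keeps the core of compound 1 but exchanges one group on an amide-type nitrogen in a ring: 4-fluorophenyl in place of cyclohexyl on an amide-type nitrogen in a ring. Within the data shown here, no measured compound tests a change at this nitrogen, so the data give no direction for it. The expectation rests only on the shared limit of the limit of > 40000 nM in this assay, at which 2 of the 2 values shown sit, which suggests weak inhibition will persist. The expected change is an at least 1.1-fold lower number from compound 1 to compound 3 (0.05 log units; that floor lies within the scatter), with no shift beyond the scatter anticipated. For compound 3 the estimated value is 35000 nM, with an expected range from 8000 nM to 80000 nM.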

Compound 3, half-maximal inhibitory concentration: > 40000 nM
Compound 3 gave a limit, no number; the forecaster's own chance of this, stated with the estimate: 65%; middle value at least 1.1-fold (0.05 log units) away from the limit.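

In this assay compound 3 gives > 40000 nM, which is a limit and not a number. Compound 1 also stands at a limit, so the exchange of cyclohexyl for 4-fluorophenyl from compound 1 to compound 3 cannot be read as a step of any size. The compounds shown leave open whether any change to this core gives a measurable value, as all of them share one result: the limit of > 40000 nM in this assay, at which 3 of the 3 values shown sit.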